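Replacing a carboxy group with an anilide on the dithioester chain

The source may hold more compounds than are shown below. What is called first, only, known or untested is meant among the compounds shown, and "the series" means these compounds.

Measured so far:
- Compound 1, `O=C(O)CCCCC(CCSC(=O)c1ccccc1)SC(=O)c1ccccc1`: 0.77%
- Compound 2, `O=C(CCCCC(S)CCS)Nc1ccc(OC(F)(F)F)cc1`: 19.1%

In a functional assay on NCI-H460 cells (Homo sapiens) for inhibition, read by MTT assay, with a stated time of 24 h, tested at 1 ug/mL (a lower number here means less inhibition of growth, a higher number more inhibition of growth at the concentration tested), compound 1 gives 0.77%, the lowest of the two numbers recorded. Its nearest neighbour is compound 2, whose value of 19.1% lies beyond the scatter above it, so compound 1 clearly shows the weaker growth inhibition of the pair. Going by the values given here, no pair of measured compounds differs in a single place, so no direct step has been measured.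

Among the compounds with values here, compound 3, `O=C(CCCCC(CCSC(=O)c1ccccc1)SC(=O)c1ccccc1)Nc1cccc(Cl)c1`, is the first single-point change from compound 1: (3-chlorophenyl)amino in place of hydroxy on a carbonyl carbon. The shared core, with its two thiobenzoyl groups on the chain, is untouched.

Within the data shown here, with no measured step to lean on, the expectation rests on the two values alone. Among the measured compounds shown here, a modest rise in growth inhibition is expected for compound 3, because compound 2, the only other measured compound, gives 19.1% while keeping a chain of similar length. The step from compound 1 to compound 3 is estimated as a number 8.2 percentage points higher from compound 1 to compound 3 (within the scatter), a size near the edge of the scatter. Compound 3 is therefore estimated at 9%, with a range from -4% to 24%.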

Compound 3, percent growth inhibition at one concentration: 9.48%
The estimate for compound 3 lay 0.5 percentage points below the measured number, within the range that was stated.
By their numbers in this assay, from the lowest: compounds 1, 3 and 2 (each within the scatter of the next, the first and the last beyond it).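

Going by these compounds alone, replacing hydroxy with (3-chlorophenyl)amino on a carbonyl carbon is the first change in a single place that can be read in this assay, and the step comes to a number 8.7 percentage points higher from compound 1 to compound 3 (within the scatter). This exchange puts 8 heavy atoms and a six-membered aromatic ring where 1 oxygen stood, with the two thiobenzoyl groups left in place, yet the step does not clear the usual scatter, so this result alone does not separate the carboxy compound from the (3-chlorophenyl)carbamoyl compound. No measurement bears on why the step has this size.

Within the data shown here, it remains open whether a clear difference at this carbonyl carbon would appear with another group there, such as a plain phenylamino group, a methoxy group as in a methyl ester, or a 4-(trifluoromethoxy)phenylamino group like the one in compound 2. Also open, on these data alone, is what the two thiobenzoyl groups contribute, which a direct exchange for free thiols on compound 3 would address, since compound 2 differs from compound 3 in more than one place and cannot settle that question.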